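The source may report more compounds than this note shows. Statements on the series, on what has been measured and on what is new or still open speak of the compounds shown alone.

In a functional assay on Jurkat cells (Homo sapiens) for antiproliferative activity, read by MTT assay, with a stated time of 72 h; a lower number here means a stronger inhibitor, a higher number a weaker inhibitor:
- compound 1 `COc1cc(C(=O)c2sc3ccccc3c2-c2ccccc2)cc(OC)c1OC`: 1500 nM
- compound 2 `COc1cc(C(=O)c2sc3ccccc3c2-c2ccc(C)cc2)cc(OC)c1OC`: 3300 nM
- compound 3 `COc1cc(C(=O)c2sc3ccccc3c2-c2ccc(SC)cc2)cc(OC)c1OC`: 1900 nM

Compound 3 lies within the scatter of both other compounds: a 1.3-fold higher number from compound 1 to compound 3 (0.10 log units; within the scatter) and a 1.7-fold lower number from compound 2 to compound 3 (0.24 log units; within the scatter). Compound 4 `COc1ccc(-c2c(C(=O)c3cc(OC)c(OC)c(OC)c3)sc3ccccc23)cc1C` is unmeasured. It differs from compound 3 as follows: 4-methoxy-3-methylphenyl in place of 4-(methylsulfanyl)phenyl on an aromatic carbon.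

For the measured compounds named here, the only step beyond the scatter is modest: a 2.2-fold higher number from compound 1 to compound 2 (0.34 log units; beyond the scatter). Going by the values given here, no measured compound carries 4-methoxy-3-methylphenyl, so the evidence is indirect. Among the compounds with values here, with changes at this place so far as small as a 2.2-fold higher number from compound 1 to compound 2 (0.34 log units; beyond the scatter), no step beyond the scatter is expected in this assay. The expected step is a 1.5-fold lower number from compound 3 to compound 4 (0.16 log units; within the scatter). For compound 4 the estimated value is 1300 nM, with an expected range of 250 nM to 4500 nM.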

Compound 4, half-maximal inhibitory concentration: > 10000 nM
Compound 4: no number, only a limit; the forecaster's own chance of this, stated with the estimate: 3%; at least 7.6-fold (0.88 log units) between middle value and limit.
By their numbers in this assay, from the lowest: compounds 1, 3 and 2 (each within the scatter of the next, the first and the last beyond it). At a limit, above all of these: compound 4.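

For compound 4, the reading in this assay is a limit, not a number: the limit of > 10000 nM in this assay, at which 1 of the 4 values shown sits.

Changes at this place are therefore not confined to modest steps: the series shows an at least 6.6-fold higher number from compound 1 to compound 4 (0.82 log units; beyond the scatter), an at least 3.0-fold higher number from compound 2 to compound 4 (0.48 log units; beyond the scatter) and an at least 5.2-fold higher number from compound 3 to compound 4 (0.72 log units; beyond the scatter). The aromatic group at this place can thus move the reading well beyond the scatter, which the phenyl, 4-methylphenyl and 4-(methylsulfanyl)phenyl compounds had not shown.

Which part of 4-methoxy-3-methylphenyl, the methoxy or the methyl, carries these steps stays open. Also open, going by these compounds, is how a phenyl bearing an amine or a carboxylic acid would read.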